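The compounds below may be only part of what the source reports. "The series", "measured", "known", "first", "only" and "open" are said of these compounds alone.

Among the measured compounds shown here, compound 1 `CCn1ccc2cc(NC(=O)CN(c3cc(Cl)ccc3OC)S(=O)(=O)c3ccccc3)ccc21` gives 2220 nM in a functional assay on SH-SY5Y cells (Homo sapiens), read by MTT assay, with a stated time of 24 h (on this read-out lower numbers stand for an effect already at smaller amounts and higher numbers for an effect only at larger amounts of compound), and is the only member of this set with an actual number. Compound 2 `COc1ccc(Cl)cc1N(CC(=O)N1CCc2ccccc21)S(=O)(=O)c1ccccc1` returns no number in this assay but a limit, > 20000 nM. Of the two values shown, one sits at the limit of > 20000 nM in this assay, at which 1 of the 2 values shown sits, so compound 1 stands alone as the reference point. Compound 3 `COc1cccc(NC(=O)CN(c2cc(Cl)ccc2OC)S(=O)(=O)c2ccccc2)c1` differs from compound 1 by 3-methoxyphenyl in place of 1-ethyl-1H-indol-5-yl on an amide-type nitrogen. For the measured compounds named here, no measured step of this kind is available, so the size of the change is open; a move toward weaker effect beyond the scatter is expected, a 2.7-fold higher number from compound 1 to compound 3 (0.43 log units; beyond the scatter). For compound 3 a value of about 6000 nM is estimated, within 2500 nM to 20000 nM.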

Compound 3, half-maximal effective concentration: 17600 nM
Compound 3: middle estimate off by 2.9-fold (0.47 log units), on the low side; measured number inside the range.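

On an amide-type nitrogen, 3-methoxyphenyl in place of 1-ethyl-1H-indol-5-yl gives a 7.9-fold higher number from compound 1 to compound 3 (0.90 log units; beyond the scatter) as a modest step and the first measured size for a change at this place, with hydrogen-bond donor and acceptor counts the same on both groups. Compound 2 holds > 20000 nM as a limit of the assay and not a number. Among the compounds shown here, on a carbonyl carbon, (3-methoxyphenyl)amino in place of 2,3-dihydro-1H-indol-1-yl gives an at least 1.1-fold lower number from compound 2 to compound 3 (0.05 log units; that floor lies within the scatter) as the only reading of that step, and it fixes no size. Nothing shown accounts for the size of the step at this nitrogen.

Open, going by these compounds, is whether the ethyl group or the two-ring system carries the difference. Also open, on these data alone, is how 1-methyl-1H-indol-5-yl, or a phenyl bearing an amine or a carboxylic acid, would compare on this nitrogen.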